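Swapping the Aryl Group on the Acyl Urea

The source may hold more compounds than are shown below. What is called first, only, known or untested is meant among the compounds shown, and "the series" means these compounds.

Three compounds share a core in which a thiazole-type amide is capped by an acyl urea. Compound 1 `CN(C(=O)NC(=O)c1ccc(Cl)cc1Cl)c1nc(C(F)(F)F)c(C(=O)N/N=C/c2ccc(C(F)(F)F)cc2)s1` gives 3.08 ug/mL in a functional assay on BCG823 cells (Homo sapiens) for inhibition, read by MTT assay, with a stated time of 72 h; on this read-out lower numbers stand for stronger inhibition and higher numbers for weaker inhibition. Compound 2 `CN(C(=O)NC(=O)c1cccc(C(F)(F)F)c1)c1nc(C(F)(F)F)c(C(=O)N/N=C/c2ccccc2C(F)(F)F)s1` gives 7.29 ug/mL in this assay. Compound 3 `Cc1nc(N(C)C(=O)NC(=O)c2ccc(Cl)cc2Cl)sc1C(=O)N/N=C/c1ccc(C(F)(F)F)cc1` gives 38 ug/mL in this assay, the highest of the three numbers, so the weakest inhibitor shown; the step of a 12-fold higher number from compound 1 to compound 3 (1.09 log units; beyond the scatter) came from methyl in place of trifluoromethyl on an aromatic carbon of the core, and compound 2 sits lower than compound 3 by a gap beyond the scatter.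

Compound 4 `Cc1nc(N(C)C(=O)NC(=O)c2c(F)cccc2F)sc1C(=O)N/N=C/c1ccc(C(F)(F)F)cc1` keeps the methyl core of compound 3 and changes only the aryl group on the acyl urea: 2,6-difluorophenyl in place of 2,4-dichlorophenyl on a carbonyl carbon. For the measured compounds named here, no measured step touches this position alone; compound 2 carries a different aryl there but also differs at two other places, so it cannot serve as a guide. With nothing to anchor the change, no step beyond the scatter is expected in this assay, and compound 4 is estimated at 40 ug/mL (range 12 ug/mL to 130 ug/mL), an expected step of a 1.1-fold higher number from compound 3 to compound 4 (0.02 log units; within the scatter).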

Compound 4, half-maximal inhibitory concentration: 65.5 ug/mL
Compound 4: middle estimate off by 1.6-fold (0.21 log units), on the low side; measured number inside the range.
By their numbers in this assay, from the lowest: compound 1; then compound 2; then compounds 3 and 4 (each within the scatter of the next).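

For the compounds shown here, this is the first step measured at the aryl group on the acyl urea. In this assay the change of 2,4-dichlorophenyl to 2,6-difluorophenyl on a carbonyl carbon gives a 1.7-fold higher number from compound 3 to compound 4 (0.24 log units; within the scatter) and so does not separate the two compounds, while the one step beyond the scatter among these single changes remains a 12-fold higher number from compound 1 to compound 3 (1.09 log units; beyond the scatter) on the core itself. No supporting measurement bears on this result, so no reason for it can be given.

From the compounds shown here alone, whether the same aryl swap would also stay within the scatter on the trifluoromethyl core of compound 1 remains open, as this step stands on the methyl core only. Also open, going by these compounds, is how an amine or a longer alkyl chain in place of the aryl group on this carbonyl carbon would read.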